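Compound 3 to compound 4: fluoro to bromo

The source may hold more compounds than are shown below. What is called first, only, known or untested is meant among the compounds shown, and "the series" means these compounds.

Compound 3 (`COc1cc2ncnc(Nc3ccc(CS(=O)(=O)/C=C/c4ccc(F)cc4)cc3)c2cc1OC`) gives > 100000 nM in a functional assay on HT-29 cells (Homo sapiens) (on this read-out higher numbers stand for weaker inhibition of growth and lower numbers for stronger inhibition of growth), as a limit and not as a number. Compound 3 thus stands at the limit of > 100000 nM in this assay, at which 1 of the 3 values shown sits, and has no exact position on the scale.

In this assay compound 2 (`COc1cc2ncnc(Nc3ccc(CS(=O)(=O)/C=C/c4ccc(Cl)cc4Cl)cc3)c2cc1OC`) gives 6000 nM as a measured number. Compound 1 (`O=S(=O)(/C=C/c1ccc(F)cc1)Cc1ccc(Nc2ncnc3ccccc23)cc1`), with another core and a 4-fluorophenyl group, gives 1000 nM as a measured number.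

Among the measured compounds shown here, compound 4 (`COc1cc2ncnc(Nc3ccc(CS(=O)(=O)/C=C/c4ccc(Br)cc4)cc3)c2cc1OC`) has no measurement yet. It carries bromo in place of fluoro on an aromatic carbon, para to a large group (bromo in place of fluoro on an aromatic carbon).

For the measured compounds named here, the only measured step on this phenyl group is an at least 16-fold higher number from compound 2 to compound 3 (1.22 log units; beyond the scatter) and it is large. That step replaces 2,4-dichlorophenyl with 4-fluorophenyl, so it is no direct reading of bromo, but it shows how far the number can move with a change on this group. On the strength of that step, a move toward a lower number is expected here, of sizeable but uncertain extent. The expected change is an at least 5.0-fold lower number from compound 3 to compound 4 (0.69 log units; beyond the scatter) and it is only loosely fixed. Compound 4 is estimated at 20000 nM with a range from 3000 nM to 100000 nM expected around it.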

Compound 4, concentration for 50% growth inhibition: 24000 nM
The estimate for compound 4 lay 1.2-fold (0.08 log units) below the measured number; low and high end bracket the measured number.
By their numbers in this assay, from the lowest: compound 1; then compound 2; then compound 4. At a limit, above all of these: compound 3.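

In this assay, among the compounds shown here, bromo in place of fluoro on this aromatic carbon gives an at least 4.1-fold lower number from compound 3 to compound 4 (0.61 log units; beyond the scatter) and is the first reading of this single exchange, with the rest of the structure unchanged. With the 4-bromophenyl group in place of the 2,4-dichlorophenyl group, a 4.0-fold higher number from compound 2 to compound 4 (0.60 log units; beyond the scatter) still remains, so a bromo at this place does not close the gap to compound 2. The upper end of the fluoro-to-bromo step stays unfixed, as compound 3 is held only as a limit and not as a number: the limit of > 100000 nM in this assay, at which 1 of the 4 values shown sits.

The compounds shown leave open how a methoxy group, an amine or a carboxylic acid would read at this place, and whether a single chloro would fall nearer to bromo or to the 2,4-dichlorophenyl group. They also leave open whether bromo in place of fluoro reads the same way on the core of compound 1, which gives 1000 nM with its 4-fluorophenyl group.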